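The source may hold more compounds than are shown below. What is called first, only, known or untested is meant among the compounds shown, and "the series" means these compounds.

Measured so far in a functional assay on NCI-H460 cells (Homo sapiens) for antiproliferative activity, read by MTT assay, with a stated time of 48 h; a higher number here means a weaker inhibitor, a lower number a stronger inhibitor:
- compound 1 `CCCCCC1(O)C(=O)Nc2ccc(Nc3ccc(F)cc3)cc21`: > 100000 nM
- compound 2 `CCCCCCC1(O)C(=O)Nc2ccc(Nc3ccc(F)cc3)cc21`: 50700 nM

The entry for compound 1, > 100000 nM, is a limit and not a number. Among the measured compounds shown here, compound 2, at 50700 nM, holds the only actual number.

The next compound is compound 3 `CCCCCCC1(O)C(=O)Nc2ccc(Nc3ccc(Cl)cc3)cc21`, reached from compound 2 by chloro in place of fluoro on an aromatic carbon, para to a large group.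

For the measured compounds named here, the one measured step is an at least 1.9-fold lower number from compound 1 to compound 2 (0.29 log units; that floor lies within the scatter). It lies on the chain, not on the halogen, and it rests on (the limit of > 100000 nM in this assay, at which 1 of the 2 values shown sits). Going by the values given here, it therefore gives no guide to this change, and no halogen pair has been measured.

No shift beyond the scatter is expected in this assay, and no direction is favoured with any confidence. The expected step is a 1.2-fold lower number from compound 2 to compound 3 (0.08 log units; within the scatter). Compound 3 is estimated at 42000 nM, with an expected range of 16000 nM to 100000 nM.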

Compound 3, half-maximal inhibitory concentration: 30300 nM
Compound 3: the middle estimate sits 1.4-fold (0.14 log units) above what was measured, and the stated range covers the measured number.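

The series now holds its first halogen pair in this assay: chloro in place of fluoro on an aromatic carbon, para to a large group, gives a 1.7-fold lower number from compound 2 to compound 3 (0.22 log units; within the scatter). At this position, the read-out therefore does not separate the two halogens. Like compound 2, compound 3 gives an actual number, 30300 nM, and not a limit, but nothing shown accounts for the small step.

On these data alone, whether a bromo group, a trifluoromethyl group, a methoxy group or plain hydrogen at this place would move the number beyond the scatter remains open. Also open, as far as these compounds go, is whether a longer chain on the shared core, alone or together with chloro, would give a clearer change than the halogen pair does.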